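Methyl on the benzyl ring: compound 2 to compound 3

This account rests on a few compounds, and the source may have more. Where it says the series, first, only, none or still open, it means among the compounds named here.

Measured so far:
- compound 1, `CN(C)CCCCCCN(C)C1=Nc2ccccc2C(CC(=O)NCc2ccccc2)N1c1ccc(-c2ccccc2)cc1`; in a functional assay on cells (Homo sapiens) for cytotoxicity, read by MTT assay, with a stated time of 48 h (a higher number here means a weaker inhibitor, a lower number a stronger inhibitor), compound 1 gives 1740 nM.
- compound 2, `CN(C)CCN1CCN(C2=Nc3ccccc3C(CC(=O)NCc3ccccc3)N2c2ccc(-c3ccccc3)cc2)CC1`; in this assay compound 2 gives 2390 nM.

Compound 2 holds the higher of the two numbers, yet the gap to compound 1 is small: a 1.4-fold higher number from compound 1 to compound 2 (0.14 log units; within the scatter). The two compounds therefore sit within the scatter of each other, and no order between them can be read from these data.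

Compound 3, `Cc1ccc(CNC(=O)CC2c3ccccc3N=C(N3CCN(CCN(C)C)CC3)N2c2ccc(-c3ccccc3)cc2)cc1`, differs from compound 2 by methyl in place of hydrogen on an aromatic carbon. Within the data shown here, the single measured step concerns the group on the carbon with a double bond to nitrogen and leaves the benzylamino part untouched; no measured step bears on the present change. The series thus gives no ground for a shift beyond the scatter in either direction. Compound 3 is expected to give 2400 nM in this assay, with a range of 1200 nM to 4800 nM. The expected step is a 1.0-fold higher number from compound 2 to compound 3 (0.00 log units; within the scatter), no change beyond the scatter.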

Compound 3, half-maximal inhibitory concentration: 3520 nM
For compound 3 the middle estimate is 1.5-fold (0.17 log units) below the measured one; low and high end bracket the measured number.
By their numbers in this assay, from the lowest: compounds 1, 2 and 3 (each within the scatter of the next, the first and the last beyond it).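

In this assay, among these compounds, the first measured change on the benzylamino part, benzyl to 4-methylbenzyl, gives a 1.5-fold higher number from compound 2 to compound 3 (0.17 log units; within the scatter) and so stays within the scatter. On this evidence, a methyl on the aromatic carbon para to a large group produces no readable shift in compound 3 relative to compound 2, and this position can carry that one added carbon in this series. No supporting measurement bears on this result.

Going by these compounds, whether a chlorine, a carboxylic acid or an aminomethyl group on this same carbon would give a step beyond the scatter remains open. Also open, on these data alone, is whether 4-methylbenzyl would give a comparable step alongside the (6-(dimethylamino)hexyl)(methyl)amino group of compound 1.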